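The compounds below may be only part of what the source reports. "The series", "measured", "known", "first", "only" and "open" are said of these compounds alone.

Compound 1 `CCc1cccc2c(OC)c(-c3occ(C)c3C(=S)OC)ccc12` gives 5.8 ug/mL in a functional assay on MDA-MB-231 cells (Homo sapiens) for cytotoxicity, read by MTT assay, with a stated time of 72 h; on this read-out higher numbers stand for an effect only at larger amounts of compound and lower numbers for an effect already at smaller amounts. Compound 2 `CCc1cccc2c(OC)c(-c3occ(C)c3CO)ccc12` reaches only a limit of the assay, > 10 ug/mL, in this assay. Compound 3 `CCOc1c(-c2occ(C)c2CO)ccc2c(CC)cccc12` gives 1.4 ug/mL in this assay.

Of the two numbers available, compound 3 holds the lower one and compound 1 the other. The step to compound 4 `CCOc1c(-c2occ(C)c2COC)ccc2c(CC)cccc12` is methyl in place of hydrogen on an oxygen on a saturated carbon. Among the measured compounds shown here, two measured steps touch on it. The change from compound 1 to compound 2 alters the same group on the shared core and gave an at least 1.7-fold higher number from compound 1 to compound 2 (0.23 log units; that floor lies within the scatter); since compound 2 sits at the limit of > 10 ug/mL in this assay, at which 1 of the 3 values shown sits, only a floor is known for that step. The change from compound 2 to compound 3 also adds a methyl, though at a different oxygen, and gave an at least 7.1-fold lower number from compound 2 to compound 3 (0.85 log units; beyond the scatter). With one step at the same site reading within the scatter and the other at a separate site, a shift in this assay for compound 4 is expected to be modest at most. Compound 4 is therefore estimated at 2.5 ug/mL, with a range from 1 ug/mL to 7 ug/mL. The expected step is a 1.8-fold higher number from compound 3 to compound 4 (0.25 log units; within the scatter).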

Compound 4, concentration for half-maximal effect: > 10 ug/mL
Compound 4 gave a limit, no number (the forecaster's own chance of this, stated with the estimate: 10%); middle value at least 4.0-fold (0.60 log units) from the limit.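

Among the compounds shown here, changing hydroxymethyl to methoxymethyl gave an at least 7.1-fold higher number from compound 3 to compound 4 (0.85 log units; beyond the scatter) in this assay, the first step at this group that lies beyond the scatter. Compound 4 stands at a limit and not at a number, so only a floor is known for the step: the limit of > 10 ug/mL in this assay, at which 2 of the 4 values shown sit. The same added methyl does not read alike at the two oxygens: at the other oxygen it gave an at least 7.1-fold lower number from compound 2 to compound 3 (0.85 log units; beyond the scatter), whereas on the oxygen of the hydroxymethyl group the number moves the opposite way.

On these data alone, how far compound 4 lies past the limit stays open. Also open, as far as these compounds go, is whether a longer chain or an acetyl ester on this oxygen, or an amine in place of the hydroxy, would keep the number near that of compound 3.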